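Series notes: extending the methoxy of compound 2

The source may report more compounds than this note shows. Statements on the series, on what has been measured and on what is new or still open speak of the compounds shown alone.

Compound 2 `COc1ccc(-c2ccn(CCC(C)C)c(=O)c2C#N)cc1Cl` stands second highest of the three measured compounds in a functional assay on CHO cells for positive allosteric modulation of metabotropic glutamate receptor 2 (Homo sapiens), read by scintillation counting and GTPgammaS binding, with a stated time of 30 min; a higher number here means a larger maximal response, a lower number a smaller maximal response: compound 2 gives 200%. Compound 1 `COc1ccc(-c2ccn(CCC(C)C)c(=O)c2C#N)cc1F` gives 160% and compound 3 `COc1ccc(-c2ccn(CCC(C)C)c(=O)c2C#N)cc1OC` gives 242%, so compound 2 lies between the two. Compound 4 `CC(C)CCn1ccc(-c2ccc(OCC3CC3)c(Cl)c2)c(C#N)c1=O` differs from compound 2 by cyclopropyl in place of hydrogen on a saturated chain carbon bound to an oxygen on an aromatic ring. The measured steps all vary the other aromatic substituent: a number 40 percentage points higher from compound 1 to compound 2 (beyond the scatter), a number 82 percentage points higher from compound 1 to compound 3 (beyond the scatter), a number 42 percentage points higher from compound 2 to compound 3 (beyond the scatter). Among the measured compounds shown here, none of them alters the methoxy, so no measured step bears directly on the present change, and no step beyond the scatter is expected in this assay in either direction. For compound 4 the expected maximal response is 200%, within a range from 150% to 260%. The expected step is no change at the digits printed from compound 2 to compound 4 (within the scatter).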

Compound 4, largest response reached (Emax), in percent of the reference or control that the assay uses: 206%
The estimate for compound 4 lay 6 percentage points below the measured number, within the range that was stated.
By their numbers in this assay, from the lowest: compound 1; then compounds 2 and 4 (each within the scatter of the next); then compound 3.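

In this assay the methoxy of compound 2 accepts extension: cyclopropyl in place of hydrogen on a saturated chain carbon bound to an oxygen on an aromatic ring gives a number 6 percentage points higher from compound 2 to compound 4 (within the scatter). Among the compounds shown here, the earlier steps varied only the other aromatic substituent, so this is the first reading at this position, and methoxy to cyclopropylmethoxy leaves the two compounds indistinguishable. Nothing available accounts for this result.

From the compounds shown here alone, whether an amine or a carboxylic acid at the end of this chain would give a similar response remains open. So does whether cyclopropylmethoxy would behave alike in compound 3.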